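From nitro to propanoylamino in a cytotoxicity series

A few compounds are considered here, and "the series" means these few. Any claim that something is new, unique, unknown or untested is made for them only; others in the source may bear on it.

In a toxicity assay on Huh-7.5 cells (Homo sapiens) for inhibition, read by MTT assay, with a stated time of 96 h (a lower number here means that less compound is tolerated, a higher number that more compound is tolerated), compound 3 `CN1CCN(Cc2ccc(NC(=O)c3ccc(OCCCCl)c([N+](=O)[O-])c3)cc2C(F)(F)F)CC1` gives 6800 nM, within the scatter of compound 1 `CN1CCN(Cc2ccc(NC(=O)c3ccc(OCCCCl)c(N)c3)cc2C(F)(F)F)CC1` at 12900 nM, while compound 2 `CCC(=O)Nc1cc(C(=O)Nc2ccc(CN3CCN(C)CC3)c(C(F)(F)F)c2)ccc1OC` gives a higher 35300 nM, beyond the scatter of compound 3. Compound 4 `CCC(=O)Nc1cc(C(=O)Nc2ccc(CN3CCN(C)CC3)c(C(F)(F)F)c2)ccc1OCCCCl` differs from compound 3 by propanoylamino in place of nitro on an aromatic carbon, ortho to a 3-chloropropoxy group. Among the compounds with values here, the one measured step at this carbon, a 1.9-fold lower number from compound 1 to compound 3 (0.28 log units; within the scatter), stayed within the scatter. Compound 2 carries propanoylamino but lacks the 3-chloropropoxy group, and its 35300 nM points to a modest rise. The expected size is a 2.4-fold higher number from compound 3 to compound 4 (0.37 log units; beyond the scatter). For compound 4 the estimated value is 16000 nM, with an expected range of 7000 nM to 36000 nM.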

Compound 4, half-maximal cytotoxic concentration: 7870 nM
For compound 4 the middle estimate is 2.0-fold (0.31 log units) above the measured one, and the stated range covers the measured number.
By their numbers in this assay, from the lowest: compounds 3, 4 and 1 (each within the scatter of the next); then compound 2.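

In this assay, propanoylamino in place of nitro on this aromatic carbon stays within the scatter, a 1.2-fold higher number from compound 3 to compound 4 (0.06 log units; within the scatter), and propanoyl in place of hydrogen on the amino nitrogen does too, a 1.6-fold lower number from compound 1 to compound 4 (0.21 log units; within the scatter), so with a 3-chloropropoxy group ortho, these three groups are not told apart. Within the data shown here, the one step beyond the scatter lies on the oxygen side, where 2-chloroethyl replaces hydrogen on the chain carbon, a 4.5-fold lower number from compound 2 to compound 4 (0.65 log units; beyond the scatter). No evidence is at hand to explain these numbers. From the compounds shown here alone, whether a carboxylic acid or a longer acylamino chain at this carbon would also stay within the scatter remains open.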